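Removing Both Chlorines from the Aryl Ring of Compound 2

The compounds below may be only part of what the source reports. "The series", "measured", "known", "first", "only" and "open" are said of these compounds alone.

Measured compounds:
compound 1 `CC(c1ccc(-c2ccccc2)c(F)c1)c1nnc2n1N=C(c1ccc(OC(F)(F)F)cc1)CS2` — 5400 nM
compound 2 `CC(c1ccc(-c2ccccc2)c(F)c1)c1nnc2n1N=C(c1ccc(Cl)cc1Cl)CS2` — 6900 nM

Within the data shown here, in a functional assay on HCT-116 cells (Homo sapiens) for inhibition, read by sulforhodamine B assay, with a stated time of 72 h (a higher number here means a weaker inhibitor, a lower number a stronger inhibitor), compound 2 gives 6900 nM, the higher of the two numbers so far; its nearest neighbour is compound 1, and the gap between the two lies within the scatter. Among the measured compounds shown here, the only measured step, a 1.3-fold higher number from compound 1 to compound 2 (0.11 log units; within the scatter), swaps one substituted aryl ring for another on the same carbon and moves the number very little.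

Compound 3 `CC(c1ccc(-c2ccccc2)c(F)c1)c1nnc2n1N=C(c1ccccc1)CS2` is not yet measured. It differs from compound 2 in one place: phenyl in place of 2,4-dichlorophenyl on a carbon with a double bond to nitrogen. This change strips both chlorine atoms from the aryl ring, leaving a bare phenyl on the carbon with a double bond to nitrogen.

For the measured compounds named here, the one step that bears on this position, from compound 1 to compound 2, stayed within the scatter, so a substantial shift in this assay is not expected from yet another variation of the same aryl ring. Compound 3 is therefore estimated at 8000 nM, with a plausible range from 3000 nM to 25000 nM. The expected step is a 1.2-fold higher number from compound 2 to compound 3 (0.06 log units; within the scatter), essentially flat.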

Compound 3, half-maximal inhibitory concentration: 9700 nM
Compound 3: the middle estimate sits 1.2-fold (0.08 log units) below what was measured; measured number inside the range.
By their numbers in this assay, from the lowest: compounds 1, 2 and 3 (each within the scatter of the next).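

With phenyl in place of 2,4-dichlorophenyl on the carbon with a double bond to nitrogen, this assay shows a 1.4-fold higher number from compound 2 to compound 3 (0.15 log units; within the scatter), and with hydrogen in place of trifluoromethoxy on an aromatic carbon it shows a 1.8-fold higher number from compound 1 to compound 3 (0.25 log units; within the scatter). The earlier compounds shown here only compared one substituted aryl ring with another, whereas these two steps show that an aryl ring with no substituent at all also stays within the scatter of both substituted rings, so neither the two chlorine atoms nor the trifluoromethoxy group is needed for a number of this size of three compounds. Nothing available explains why this position responds so little to these changes.

The three compounds all carry a carbon-only aromatic ring here, so they leave open whether an amine or a carboxylic acid on that ring, or a cyclohexyl group in its place, would move the number beyond the scatter. They also leave open how the number responds to changes elsewhere on the shared core, since the rest of the structure is the same in all three.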